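The source may hold more compounds than are shown below. What is called first, only, known or untested is meant among the compounds shown, and "the series" means these compounds.

Measured so far:
compound 1 `N#C/C(=C\c1ccccc1OS(=O)(=O)c1ccc(Cl)cc1)C(=O)Nc1nnc(Cc2ccc(F)cc2)s1`: 68%
compound 2 `COc1ccc(S(=O)(=O)Oc2ccccc2/C=C(\C#N)C(=O)Nc2nnc(Cc3ccc(Cl)cc3)s2)cc1`: 77%

In a functional assay on RS4-11 cells (Homo sapiens) for inhibition, read by CCK-8 assay, with a stated time of 48 h, tested at 20 uM (a lower number here means less inhibition of growth, a higher number more inhibition of growth at the concentration tested), compound 2 gives 77% and compound 1 gives 68%, so the two lie within the scatter of each other and neither stands apart. Compound 3 `N#C/C(=C\c1ccccc1OS(=O)(=O)c1ccc(Cl)cc1)C(=O)Nc1nnc(Cc2ccc(Cl)cc2)s1` carries chloro in place of methoxy on an aromatic carbon of compound 2, para to a large group (chloro in place of methoxy on an aromatic carbon). Among the measured compounds shown here, no measured pair isolates this change, so no step beyond the scatter is expected in this assay. The estimated a number 5 percentage points lower from compound 2 to compound 3 (within the scatter) stays within the scatter. For compound 3 the expected value is 72%, with an estimated range of 60% to 84%.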

Compound 3, percent growth inhibition at one concentration: 64%
Compound 3: middle estimate off by 8 percentage points, on the high side; the measured number falls inside the stated range.
By their numbers in this assay, from the lowest: compounds 3, 1 and 2 (each within the scatter of the next, the first and the last beyond it).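

In this assay, among the compounds shown here, 4-chlorophenyl in place of 4-methoxyphenyl on the sulfonyl group gives a number 13 percentage points lower from compound 2 to compound 3 (beyond the scatter), the first single-place comparison at this position, and a modest one. Chloro in place of fluoro at the other substituted aromatic carbon gives a number 4 percentage points lower from compound 1 to compound 3 (within the scatter), so that change cannot be told apart from no change in this read-out. Nothing at hand explains either step.

Open, going by these compounds, is how an amine or a carboxylic acid would read at the sulfonyl-bearing position. Also open, on these data alone, is whether methoxy there gives the same step when fluoro replaces chloro on the other aromatic ring.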